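Pyridine-carboxamide series: aryl swap at the pyridine

The source may hold more compounds than are shown below. What is called first, only, known or untested is meant among the compounds shown, and "the series" means these compounds.

Working notes on two measured analogues and one open position. Compound 2 `COc1cc2c(Oc3ccc(NC(=O)c4cc(-c5ccccc5C)ccn4)cc3F)ccnc2cc1OCCCN1CCCC1` gives 1150 nM in a functional assay on HT-29 cells (Homo sapiens) for cytotoxicity, read by MTT assay, with a stated time of 72 h (on this read-out lower numbers stand for stronger inhibition and higher numbers for weaker inhibition), the higher of the two numbers shown; compound 1 `COc1ccc(-c2ccnc(C(=O)Nc3ccc(Oc4ccnc5cc(OCCCN6CCCCC6)c(OC)cc45)c(F)c3)c2)cc1` gives 690 nM in this assay, and the two lie within the scatter of each other. Compound 3 `COc1ccc(-c2ccnc(C(=O)Nc3ccc(Oc4ccnc5cc(OCCCN6CCCC6)c(OC)cc45)c(F)c3)c2)cc1` carries 4-methoxyphenyl in place of 2-methylphenyl on an aromatic carbon. Among the compounds with values here, no measured pair isolates this change, so the step from compound 2 to compound 3 is expected to be small, toward a lower number or none beyond the scatter. Compound 3 is expected at 750 nM (range 350 nM to 1600 nM), an expected step of a 1.5-fold lower number from compound 2 to compound 3 (0.19 log units; within the scatter).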

Compound 3, half-maximal inhibitory concentration: 350 nM
Estimate against measurement, compound 3: 2.1-fold (0.33 log units) above; the range from low to high includes it.
By their numbers in this assay, from the lowest: compounds 3, 1 and 2 (each within the scatter of the next, the first and the last beyond it).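

In this assay, 4-methoxyphenyl in place of 2-methylphenyl opposite the ring nitrogen gives a 3.3-fold lower number from compound 2 to compound 3 (0.52 log units; beyond the scatter), showing that this position responds to the aryl group. Pyrrolidin-1-yl in place of piperidin-1-yl on the chain gives a 2.0-fold lower number from compound 1 to compound 3 (0.29 log units; within the scatter), so that swap shows no clear change. Nothing available explains the aryl step.

This single pair cannot separate the methoxy group from its place on the phenyl ring. Going by these compounds, how a 4-methylphenyl or a 2-methoxyphenyl at this position would compare remains open.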